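Swapping bromo for fluoro on a sulfonamide aryl ring

The source may hold more compounds than are shown below. What is called first, only, known or untested is meant among the compounds shown, and "the series" means these compounds.

Measured compounds:
compound 1, `COc1cc(-c2nc(-c3ccccc3)[nH]c2-c2ccnc(NCCCNS(=O)(=O)c3ccc(Br)cc3)n2)ccc1Cl`, 23700 nM
compound 2, `COc1cc(-c2nc(-c3ccccc3)[nH]c2-c2ccnc(NCCCNS(=O)(=O)c3ccc(F)cc3)n2)ccc1Cl`, 4530 nM
compound 3, `O=S(=O)(NCCCNc1nccc(-c2[nH]c(-c3ccccc3)nc2-c2ccc(F)c(O)c2)n1)c1ccc(Br)cc1`, 5660 nM

All three were tested in a functional assay on LOX IMVI cells (Homo sapiens) for cytotoxicity, read by MTT assay, with a stated time of 24 h; a lower number here means a stronger inhibitor, a higher number a weaker inhibitor. Compound 1 gives 23700 nM, the highest number of the three. Compound 2 differs from compound 1 only by fluoro in place of bromo on an aromatic carbon, and this brought a 5.2-fold lower number from compound 1 to compound 2 (0.72 log units; beyond the scatter). Compound 3 differs from compound 1 by 4-fluoro-3-hydroxyphenyl in place of 4-chloro-3-methoxyphenyl on an aromatic carbon, which brought a 4.2-fold lower number from compound 1 to compound 3 (0.62 log units; beyond the scatter). Compound 2 and compound 3 lie within the usual scatter of each other, so no order between them can be read.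

Compound 4, `O=S(=O)(NCCCNc1nccc(-c2[nH]c(-c3ccccc3)nc2-c2ccc(F)c(O)c2)n1)c1ccc(F)cc1`, has not yet been measured. It differs from compound 3 by fluoro in place of bromo on an aromatic carbon. This is the same change as that from compound 1 to compound 2, made on a different core; how the two cores differ is described above as the change from compound 1 to compound 3.

On the core of compound 1 this change gave a modest step beyond the scatter. For the measured compounds named here, with only one earlier example, and on a different core, the same direction is expected but its size is uncertain; a somewhat smaller step, a 3.8-fold lower number from compound 3 to compound 4 (0.58 log units; beyond the scatter), is estimated, resting on compound 3 at 5660 nM and on the step of a 5.2-fold lower number from compound 1 to compound 2 (0.72 log units; beyond the scatter). Compound 4 is therefore expected to give about 1500 nM, with a plausible range from 500 nM to 5000 nM.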

Compound 4, half-maximal inhibitory concentration: 19200 nM
Estimate against measurement, compound 4: 13-fold (1.11 log units) below; the measured number lies above the stated range.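

In this assay, fluoro in place of bromo did not carry over from one core to the other: here it brought a 3.4-fold higher number from compound 3 to compound 4 (0.53 log units; beyond the scatter), the opposite direction to the earlier step on the core of compound 1, and the two steps clearly differ: the same change on two cores in this assay, a 5.2-fold lower number (0.72 log units; beyond the scatter) from compound 1 to compound 2 and a 3.4-fold higher number (0.53 log units; beyond the scatter) from compound 3 to compound 4, 18-fold (1.25 log units) apart, beyond the scatter of two such steps. The same four compounds, read the other way, show that 4-fluoro-3-hydroxyphenyl in place of 4-chloro-3-methoxyphenyl also depends on its partner; with the 4-fluorophenyl group in place it brought a 4.2-fold higher number from compound 2 to compound 4 (0.63 log units; beyond the scatter), the reverse of its effect with the 4-bromophenyl group: the same change on two cores in this assay, a 4.2-fold lower number (0.62 log units; beyond the scatter) from compound 1 to compound 3 and a 4.2-fold higher number (0.63 log units; beyond the scatter) from compound 2 to compound 4, 18-fold (1.25 log units) apart, beyond the scatter of two such steps. So the two changes do not act independently in this set, and the step seen on one core cannot be assumed on the other, but a single pair on each core does not show why the direction reverses or how a third core would respond.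

The aryl change alters the methoxy and chloro positions together, so the compounds shown leave open whether the hydroxy or the ring fluoro is what reverses the halogen step. Also open, on these data alone, is whether a chloro or a methyl on the sulfonyl ring, or a longer chain in the linker, would follow either core's pattern.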